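A few compounds are considered here, and "the series" means these few. Any claim that something is new, unique, unknown or untested is made for them only; others in the source may bear on it.

Two compounds built on the shared core carry a number in an assay on CHO-K1 cells for displacement of a labelled ligand from adenosine receptor A1 (Homo sapiens), read by scintillation counting, with a stated time of 60 min; on this read-out lower numbers stand for stronger inhibition and higher numbers for weaker inhibition. Compound 1 `Nc1nc(N/N=C/c2ccc(-c3ccccn3)cc2)nc2c1ncn2[C@@H]1O[C@H](CO)[C@@H](O)[C@H]1O` gives 7540 nM, and compound 2 `COc1cc(/C=N/Nc2nc(N)c3ncn([C@@H]4O[C@H](CO)[C@@H](O)[C@H]4O)c3n2)ccc1OCc1ccccc1` gives 9140 nM. For the measured compounds named here, compound 1 stands within the scatter of compound 2, the only other measured compound, so neither number sets the other apart. Compound 3 `Nc1nc(N/N=C/c2ccc(C(F)(F)F)cc2)nc2c1ncn2[C@@H]1O[C@H](CO)[C@@H](O)[C@H]1O` awaits measurement in this assay. It differs from compound 1 by trifluoromethyl in place of pyridin-2-yl on an aromatic carbon. Going by the values given here, no measured pair shows this change, so the numbers give no direction for it; a step no larger than the scatter is expected. Compound 3 is expected at 7000 nM, with a range from 2500 nM to 20000 nM. The expected step is a 1.1-fold lower number from compound 1 to compound 3 (0.03 log units; within the scatter).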

Compound 3, inhibition constant: 37 nM
Estimate against measurement, compound 3: 190-fold (2.28 log units) above; measured number outside the range, below it.
By their numbers in this assay, from the lowest: compound 3; then compounds 1 and 2 (each within the scatter of the next).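

This position, on an aromatic carbon para to a large group, is sensitive to its substituent: trifluoromethyl in place of pyridin-2-yl gives a 200-fold lower number from compound 1 to compound 3 (2.31 log units; beyond the scatter) in this assay. The lower number comes with the group that has fewer heavy atoms, no ring and no hydrogen-bond acceptor, so a ring at this carbon is not required for a number this low. Nothing measured here accounts for the step. As far as these compounds go, it remains open whether the step belongs to trifluoromethyl itself or to the loss of pyridin-2-yl. A chlorine atom, a methyl group or an unsubstituted phenyl at this carbon would help separate the two.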